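This account rests on a few compounds, and the source may have more. Where it says the series, first, only, none or still open, it means among the compounds named here.

Working notes on the series. Compound 1 `COc1ncc(-c2ccc3nc(NC(C)=O)nn3c2)cc1NS(=O)(=O)c1ccc(F)cc1` carries an acetyl on a nitrogen on an aromatic ring, and in a functional assay on U-87MG ATCC cells (Homo sapiens) for antiproliferative activity, read by MTT assay, with a stated time of 48 h (on this read-out higher numbers stand for weaker inhibition and lower numbers for stronger inhibition), compound 1 gives 1820 nM. Compound 2 `COc1ncc(-c2ccc3nc(N)nn3c2)cc1NS(=O)(=O)c1ccc(F)cc1` has a hydrogen on that nitrogen instead; in this assay compound 2 gives 3950 nM. Compound 3 `COc1ncc(-c2ccc3nc(N)nn3c2)cc1NS(=O)(=O)c1ccc(Cl)cc1` has chloro in place of fluoro on an aromatic carbon; in this assay compound 3 gives 3110 nM. Of the three numbers, compound 2 has the highest, though its gap to compound 3 lies within the scatter (a 1.3-fold lower number from compound 2 to compound 3 (0.10 log units; within the scatter)), while its gap to compound 1 lies beyond it (a 2.2-fold higher number from compound 1 to compound 2 (0.34 log units; beyond the scatter)).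

Compound 4 `CCOCCNc1nc2ccc(-c3cnc(OC)c(NS(=O)(=O)c4ccc(F)cc4)c3)cn2n1` is not yet measured. Relative to compound 2 the change is 2-ethoxyethyl in place of hydrogen on a nitrogen on an aromatic ring; amino becomes (2-ethoxyethyl)amino. The step that bears directly on this is a 2.2-fold higher number from compound 1 to compound 2 (0.34 log units; beyond the scatter), in which taking a group off the same nitrogen gave a modest rise in the number. The step of a 1.3-fold lower number from compound 2 to compound 3 (0.10 log units; within the scatter) concerns the fluoro-to-chloro exchange and offers no guide here. A 2-ethoxyethyl is a different group from an acetyl, so the expectation is only a modest move downward, a 1.8-fold lower number from compound 2 to compound 4 (0.25 log units; within the scatter). For compound 4 the expected value in this assay is 2200 nM, with a range from 800 nM to 6000 nM.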

Compound 4, half-maximal inhibitory concentration: 8150 nM
Estimate against measurement, compound 4: 3.7-fold (0.57 log units) below, outside the stated range (above it).
By their numbers in this assay, from the lowest: compounds 1, 3 and 2 (each within the scatter of the next, the first and the last beyond it); then compound 4.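

In this assay, going by these compounds alone, the earlier compounds showed only that taking the acetyl off this nitrogen raised the number, whereas putting 2-ethoxyethyl on it in place of hydrogen raises the number too, with a 2.1-fold higher number from compound 2 to compound 4 (0.31 log units; beyond the scatter). Within the data shown here, a group on this nitrogen therefore does not lower the number in itself: acetyl and 2-ethoxyethyl lie on opposite sides of hydrogen, each beyond the scatter, and the two substituted compounds are separated by a 4.5-fold higher number from compound 1 to compound 4 (0.65 log units; beyond the scatter), the widest step at this position so far. No data at hand explain why the number rises with 2-ethoxyethyl.

What the compounds shown leave open is which part of the 2-ethoxyethyl group goes with the rise, a question that a plain pentyl chain, a shorter 2-methoxyethyl group or a chain ending in a dimethylamine on the same nitrogen would help to settle. On these data alone, it also remains open whether a larger acyl group such as propionyl or benzoyl continues the direction set by acetyl, and whether the order at this nitrogen holds with chloro in place of fluoro.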